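Methylamino Replaces Fluoro on the Shared Core

A few compounds are considered here, and "the series" means these few. Any claim that something is new, unique, unknown or untested is made for them only; others in the source may bear on it.

Three urea compounds built on one shared core have been measured in a functional assay on NCI-H460 cells (Homo sapiens) for cytotoxicity, read by MTT assay, with a stated time of 72 h; on this read-out higher numbers stand for weaker inhibition and lower numbers for stronger inhibition. Compound 1 `O=C(Nc1ccc(-n2ncc3c(C(F)(F)F)cccc32)cc1)Nc1ccc(Cl)c(C(F)(F)F)c1` gives 1600 nM. Compound 2 `O=C(Nc1ccc(-n2ncc3c(Cl)cccc32)cc1)Nc1ccc(Cl)c(C(F)(F)F)c1` gives 1300 nM, and the step of a 1.2-fold lower number from compound 1 to compound 2 (0.09 log units; within the scatter) lies within the scatter, so these two cannot be ranked. Among the compounds with values here, compound 3 `O=C(Nc1ccc(-n2ncc3c(F)cccc32)cc1)Nc1ccc(Cl)c(C(F)(F)F)c1` gives 3400 nM, the highest number of the three: the steps of a 2.1-fold higher number from compound 1 to compound 3 (0.33 log units; beyond the scatter) and a 2.6-fold higher number from compound 2 to compound 3 (0.42 log units; beyond the scatter) are both modest but beyond the scatter, so compound 3 is the weakest compound measured so far.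

Compound 4 `CNc1cccc2c1cnn2-c1ccc(NC(=O)Nc2ccc(Cl)c(C(F)(F)F)c2)cc1` is the next step from compound 3. The change is methylamino in place of fluoro on an aromatic carbon. Within the data shown here, no measured step involves methylamino, so the only steps that bear on this one are the two at the same position, where fluoro gave a higher number than chloro or trifluoromethyl. Read in reverse, both say that replacing fluoro there lowered the number modestly. Methylamino is a different kind of group from either, so the expectation is uncertain, but a modest drop or no change beyond the scatter seems most likely. Compound 4 is therefore estimated at 2000 nM, within 700 nM to 6000 nM, which means an expected step of a 1.7-fold lower number from compound 3 to compound 4 (0.23 log units; within the scatter).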

Compound 4, half-maximal inhibitory concentration: 2600 nM
Compound 4: the middle estimate sits 1.3-fold (0.11 log units) below what was measured; low and high end bracket the measured number.
By their numbers in this assay, from the lowest: compounds 2, 1, 4 and 3 (each within the scatter of the next, the first and the last beyond it).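

Methylamino differs from the three groups tried so far at this position on the shared core: it is the first to hold nitrogen there, and it brings a hydrogen-bond donor and a hydrogen-bond acceptor that fluoro lacks. Even so, this assay shows a 1.3-fold lower number from compound 3 to compound 4 (0.12 log units; within the scatter), so this exchange cannot be told apart from no change at all. The comparisons with the other two groups read the same way, with a 1.6-fold higher number from compound 1 to compound 4 (0.21 log units; within the scatter) and a 2.0-fold higher number from compound 2 to compound 4 (0.30 log units; within the scatter), so compound 4 cannot be ranked against any of the three earlier compounds, even though the two ends of the set are separated by a 2.6-fold higher number from compound 2 to compound 3 (0.42 log units; beyond the scatter).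

Going by these compounds, whether a plain amine, dimethylamino or a carboxylic acid at this position would shift the number beyond the scatter remains open, and so does whether the hydrogen on the methylamino nitrogen makes any difference. No measurement at hand offers a reason for these results.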